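A few compounds are considered here, and "the series" means these few. Any claim that something is new, unique, unknown or untested is made for them only; others in the source may bear on it.

Compound 1 `O=C1O/C(=C\Cn2cc(Cc3ccccc3)nn2)C(OCc2ccccc2)=C1OCc1ccccc1` was examined in an ADME assay on HEK293 cells (Homo sapiens) for cytotoxicity, read by MTT assay, with a stated time of 24 h (a higher number here means a weaker inhibitor, a lower number a stronger inhibitor), where compound 1 gives 70000 nM. Compound 2 `O=C1NC(O)(CCn2cc(C3=CCCCC3)nn2)C(OCc2ccccc2)=C1OCc1ccccc1` gives 70000 nM in this assay, and the two values show no change beyond the scatter. Compound 3 `CC(C)(C)c1ccc(-c2cn(C/C=C3\OC(=O)C(OCc4ccccc4)=C3OCc3ccccc3)nn2)cc1` has not yet been measured in this assay. Compound 3 differs from compound 1 by 4-(tert-butyl)phenyl in place of benzyl on an aromatic carbon, on an aromatic carbon of the shared core. Going by the values given here, no measured step covers such a change, so the expected shift is only a 1.2-fold lower number from compound 1 to compound 3 (0.07 log units; within the scatter), within the scatter. Compound 3 is therefore expected to give 60000 nM, with a range from 30000 nM to 100000 nM.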

Compound 3, half-maximal inhibitory concentration: > 100000 nM
Compound 3: a limit, no number; the forecaster's own chance of this, stated with the estimate: 20%; middle value at least 1.6-fold (0.22 log units) from the limit.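

an at least 1.4-fold higher number from compound 1 to compound 3 (0.15 log units; that floor lies within the scatter) is the first step seen at this position of the shared core, with 4-(tert-butyl)phenyl in place of benzyl on an aromatic carbon. As far as these compounds go, it has only a floor, so its full size stays unknown, but this change brought no lower number in this assay. The result for compound 3 is a limit and not a number: the limit of > 100000 nM in this assay, at which 1 of the 3 values shown sits.

From the compounds shown here alone, whether the step exceeds the scatter remains open. So does whether an amine, a carboxylic acid or a longer chain at this position would give a measurable value in this assay.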